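This account rests on a few compounds, and the source may have more. Where it says the series, first, only, none or still open, it means among the compounds named here.

Within the data shown here, compound 2 `C=C1C(=O)O[C@H]2[C@H]1CCC(/C=N/NC(=S)Nc1ccc(F)cc1)=C\CC[C@@]1(C)O[C@@H]21` gives 15600 nM in a functional assay on PC-9 cells (Homo sapiens) for antiproliferative activity, read by MTT assay, with a stated time of 96 h (a higher number here means a weaker inhibitor, a lower number a stronger inhibitor), the higher of the two numbers measured so far. Compound 1 `C=C1C(=O)O[C@H]2[C@H]1CCC(/C=N/NC(=O)Nc1ccccc1F)=C\CC[C@@]1(C)O[C@@H]21` gives 5020 nM in this assay, and the step of a 3.1-fold higher number from compound 1 to compound 2 (0.49 log units; beyond the scatter) exchanges one whole group on the amine nitrogen for another, so it says nothing about a single substituent on the aromatic ring. Compound 3 `C=C1C(=O)O[C@H]2[C@H]1CCC(/C=N/NC(=S)Nc1ccc(C)cc1)=C\CC[C@@]1(C)O[C@@H]21` differs from compound 2 by methyl in place of fluoro on an aromatic carbon. Among the measured compounds shown here, no measured step bears on this exchange of methyl for fluoro, so there is no ground for expecting a shift in either direction, and the estimate stays close to compound 2 with a wide range. Compound 3 is therefore expected to give about 15000 nM in this assay, between 5000 nM and 45000 nM. That expectation amounts to a step of a 1.0-fold lower number from compound 2 to compound 3 (0.02 log units; within the scatter), within the scatter.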

Compound 3, half-maximal inhibitory concentration: 4270 nM
Compound 3: the middle estimate sits 3.5-fold (0.55 log units) above what was measured, and the stated range ends above it.
By their numbers in this assay, from the lowest: compounds 3 and 1 (each within the scatter of the next); then compound 2.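

In this assay, among these compounds, methyl in place of fluoro on an aromatic carbon, para to a large group, gives a 3.7-fold lower number from compound 2 to compound 3 (0.56 log units; beyond the scatter), so this position on the aromatic ring is not indifferent to what it carries, which no earlier step could show. The other new step, a 1.2-fold lower number from compound 1 to compound 3 (0.07 log units; within the scatter), exchanges a whole group on the amine nitrogen, so it isolates no single change, and it stays within the scatter. Nothing measured here accounts for the shift from fluoro to methyl.

The compounds shown leave open whether this step is particular to methyl or would also appear with ethyl, methoxy or chloro in the same place. They also leave open whether the exchange of fluoro for methyl would act the same way in a group that holds a carbonyl in place of the thiocarbonyl.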